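From Fluoro to Chloro on an Aromatic Carbon

The source may hold more compounds than are shown below. What is called first, only, known or untested is meant among the compounds shown, and "the series" means these compounds.

In a functional assay on SMMC-7721 cells (Homo sapiens) for inhibition, read by CCK-8 assay, with a stated time of 72 h (on this read-out higher numbers stand for weaker inhibition and lower numbers for stronger inhibition), compound 1 (`Nc1ccccc1NC(=O)c1ccc(CNC(=O)c2n[nH]cc2NC(=O)c2ccccc2Cl)cc1`) gives 12900 nM and compound 2 (`O=C(NO)c1ccc(CNC(=O)c2n[nH]cc2NC(=O)c2ccccc2F)cc1`) gives 16700 nM with the two values inside the usual scatter of each other. Compound 3 (`O=C(NO)c1ccc(CNC(=O)c2n[nH]cc2NC(=O)c2ccccc2Cl)cc1`) has not yet been measured. It differs from compound 2 by one swap (chloro in place of fluoro on an aromatic carbon) with chloro in place of fluoro on an aromatic carbon, ortho to a large group. Among the measured compounds shown here, no measured pair shows this swap, so in this assay no step beyond the scatter is expected, in either direction. The estimated step (a 1.2-fold lower number from compound 2 to compound 3 (0.08 log units; within the scatter)) is small. For compound 3 the estimate is 14000 nM with an expected range from 6000 nM to 32000 nM as its limits.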

Compound 3, half-maximal inhibitory concentration: 21800 nM
Beside the measured number, compound 3's estimate is 1.6-fold (0.19 log units) below it; the measured number falls inside the stated range.
By their numbers in this assay, from the lowest: compounds 1, 2 and 3 (each within the scatter of the next).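

In this assay, among the compounds shown here, the first pair that differs only at this position reads a 1.3-fold higher number from compound 2 to compound 3 (0.12 log units; within the scatter), so fluoro and chloro on this aromatic carbon cannot be told apart here. With chloro held fixed, hydroxy in place of 2-aminophenyl on an amide-type nitrogen gives a 1.7-fold higher number from compound 1 to compound 3 (0.23 log units; within the scatter), so that change cannot be told apart from the scatter either.

From the compounds shown here alone, whether a methoxy group or an amine on this aromatic carbon would give a step beyond the scatter remains open. No measured evidence here explains why these values lie so close together.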